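This account rests on a few compounds, and the source may have more. Where it says the series, first, only, none or still open, it means among the compounds named here.

Measured in a functional assay on Raji cells (Homo sapiens) for antiproliferative activity, read by MTT assay, with a stated time of 48 h; on this read-out lower numbers stand for stronger inhibition and higher numbers for weaker inhibition:

- Compound 1 `CCN(CC)CCCn1c(N)c(-c2nc3ccccc3[nH]2)c2nc(C#N)c(C#N)nc21`: 1870 nM
- Compound 2 `CN1CCN(CCCn2c(N)c(-c3nc4ccccc4[nH]3)c3nc(C#N)c(C#N)nc32)CC1`: 2620 nM
- Compound 3 `N#Cc1nc2c(-c3nc4ccccc4[nH]3)c(N)n(CCCO)c2nc1C#N`: > 50000 nM, a limit of the assay and not a number

Among the measured compounds shown here, no measured compound stands clearly ahead of compound 1. Its nearest neighbour lies within the scatter, as a 1.4-fold higher number from compound 1 to compound 2 (0.15 log units; within the scatter) shows, while an at least 26-fold higher number from compound 1 to compound 3 (1.42 log units; beyond the scatter) is large and beyond it. The other step to the hydroxy chain, an at least 19-fold higher number from compound 2 to compound 3 (1.28 log units; beyond the scatter), is also large. Both of these large steps end at the limit of > 50000 nM in this assay, at which 1 of the 3 values shown sits.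

Compound 4 `CCN(CC)CCCn1c(N)c(-c2nc3ccccc3n2C)c2nc(C#N)c(C#N)nc21` keeps the diethylamino chain and has methyl in place of hydrogen on an aromatic nitrogen. For the measured compounds named here, none of the measured steps touches that nitrogen, for all three change the chain alone. They therefore give no direct measure of this change. They bear on it only indirectly: the large steps went with loss of the amine chain, which compound 4 retains from compound 1 at 1870 nM. No step beyond the scatter is therefore expected in this assay, though the untested change calls for a wide range, reaching further towards higher numbers. The expected change is a 1.3-fold higher number from compound 1 to compound 4 (0.13 log units; within the scatter). For compound 4 the estimated value is 2500 nM, with an expected range from 700 nM to 10000 nM.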

Compound 4, half-maximal inhibitory concentration: 2220 nM
The estimate for compound 4 lay 1.1-fold (0.05 log units) above the measured number; low and high end bracket the measured number.
By their numbers in this assay, from the lowest: compounds 1, 4 and 2 (each within the scatter of the next). At a limit, above all of these: compound 3.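

In this assay, going from 1H-benzimidazol-2-yl to 1-methyl-1H-benzimidazol-2-yl gives a 1.2-fold higher number from compound 1 to compound 4 (0.07 log units; within the scatter), so the two compounds cannot be told apart on this read-out. Among the compounds shown here, the earlier compounds differed in the chain alone, whereas this pair gives the first direct reading at the aromatic nitrogen of the five-membered ring, and it shows that, with the diethylamino chain kept, the hydrogen on that nitrogen can be replaced by methyl without a step beyond the scatter. Nothing measured here gives a reason for this outcome.

For the compounds shown here, whether methyl on this nitrogen gives a similar reading alongside the 4-methylpiperazin-1-yl chain or the hydroxy chain remains open, since the single pair carries the diethylamino chain. Also open is what a larger group on the same nitrogen, such as ethyl, benzyl or acetyl, would do, as methyl is the only replacement for hydrogen there among the compounds shown.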